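From an aryl amide to a pyridyl amide on a shared core

This account rests on a few compounds, and the source may have more. Where it says the series, first, only, none or still open, it means among the compounds named here.

Three measured compounds share one core, seen in compound 1 `CC(C)C(=O)Nc1c(C(O)(C(F)(F)F)C(F)(F)F)ccc2ccccc12`, and differ only in the group on the carbonyl carbon of the amide. In an assay on LtK cells with ATP-sensitive inward rectifier potassium channel 11 (Homo sapiens) as the target (a lower number here means that less compound is needed, a higher number that more compound is needed for the effect), compound 1 gives 6630 nM. Compound 2 `C/C=C/C(=O)Nc1c(C(O)(C(F)(F)F)C(F)(F)F)ccc2ccccc12` carries prop-1-en-1-yl on that carbon and gives 72 nM; this is a 92-fold lower number from compound 1 to compound 2 (1.96 log units; beyond the scatter). Compound 3 `O=C(Nc1c(C(O)(C(F)(F)F)C(F)(F)F)ccc2ccccc12)c1ccc(OC(F)(F)F)cc1` carries 4-(trifluoromethoxy)phenyl on that carbon. For compound 3 the assay reports only a limit, > 10000 nM, not a number (the limit of > 10000 nM in this assay, at which 1 of the 3 values shown sits). Set against the others, an at least 1.5-fold higher number from compound 1 to compound 3 (0.17 log units; that floor lies within the scatter), and an at least 130-fold higher number from compound 2 to compound 3 (2.14 log units; beyond the scatter), so compound 3 is far from compound 2 and not separated from compound 1 beyond the scatter.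

Compound 4 `O=C(Nc1c(C(O)(C(F)(F)F)C(F)(F)F)ccc2ccccc12)c1cccnc1` is the unmeasured step: pyridin-3-yl in place of 4-(trifluoromethoxy)phenyl on a carbonyl carbon. For the measured compounds named here, no measured step involves pyridin-3-yl itself, so the two steps ending at compound 3 are the only guide, and the one aromatic group measured on the carbonyl carbon, in compound 3, reached the limit. Compound 4 is therefore expected to stay near that limit, with a step that the limit leaves unreadable from compound 3 to compound 4 that carries little weight in either direction. The estimate for compound 4 is 15000 nM, within the range 3000 nM to 60000 nM.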

Compound 4, half-maximal effective concentration: 60 nM
Compound 4: the middle estimate sits 250-fold (2.40 log units) above what was measured; the whole stated range lies above it.
By their numbers in this assay, from the lowest: compounds 4 and 2 (each within the scatter of the next); then compound 1. At a limit, above all of these: compound 3.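

An aromatic ring on the carbonyl carbon does not by itself go with a high number in this assay: putting pyridin-3-yl in place of 4-(trifluoromethoxy)phenyl gives an at least 160-fold lower number from compound 3 to compound 4 (2.22 log units; beyond the scatter). Compound 4 also stands level with the non-aromatic prop-1-en-1-yl amide, with a 1.2-fold lower number from compound 2 to compound 4 (0.08 log units; within the scatter), and both stand well clear of the isopropyl amide, with a 110-fold lower number from compound 1 to compound 4 (2.04 log units; beyond the scatter). For compound 3 there is only a limit, so the step from it gives a floor and not a full size: the limit of > 10000 nM in this assay, at which 1 of the 4 values shown sits.

The change from compound 3 to compound 4 swaps the ring nitrogen in and the trifluoromethoxy group out at the same time, so the compounds shown cannot say which of the two goes with the large step, and plain phenyl on the same carbonyl carbon would separate them. Also open, on these data alone, is whether the place of the ring nitrogen matters, which pyridin-2-yl and pyridin-4-yl would test, and whether any other ring on this carbon, such as pyrimidin-5-yl, behaves like pyridin-3-yl.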